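The source may report more compounds than this note shows. Statements on the series, on what has been measured and on what is new or still open speak of the compounds shown alone.

Measured compounds:
- Compound 1 `COc1ccc(F)cc1CNCCCNc1ccnc2cc(Cc3cc(C)cc(C)c3)ccc12`: in an ADME assay for permeability, using PAMPA, with a stated time of 30 min, at pH 7.4 (on this read-out lower numbers stand for lower permeability and higher numbers for higher permeability), compound 1 gives 23 10^-6 cm/s.
- Compound 2 `Fc1ccc(Oc2ccc3c(NCCCNCc4ccco4)ccnc3c2)cc1`: in this assay compound 2 gives 317 10^-6 cm/s.
- Compound 3 `COc1ccc(F)cc1CNCCCNc1ccnc2cc(Cc3ccccc3)ccc12`: in this assay compound 3 gives 23 10^-6 cm/s.

Compound 3 stands level with compound 1, the two together being the lowest of the three numbers, while compound 2 gives the highest. For the measured compounds named here, the one single-point step among them, no change at the digits printed from compound 1 to compound 3 (within the scatter), shows that exchanging phenyl for 3,5-dimethylphenyl at that carbon left the number unchanged within the scatter.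

Compound 4 `COc1ccc(F)cc1CNCCCNc1ccnc2cc(Oc3ccc(F)cc3)ccc12` is not yet measured. It differs from compound 3 by 4-fluorophenoxy in place of benzyl on an aromatic carbon. Going by the values given here, no measured step covers this exchange directly. Compound 2 carries the same 4-fluorophenoxy group and gives the highest number, but it also differs from compound 3 elsewhere, so its value cannot be assigned to this change alone. A modest rise is therefore expected, but with wide uncertainty: the step of a 2.2-fold higher number from compound 3 to compound 4 (0.34 log units; beyond the scatter) is estimated as an increase. For compound 4 the expected value in this assay is 50 10^-6 cm/s, with a range from 15 10^-6 cm/s to 180 10^-6 cm/s.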

Compound 4, apparent permeability: 317 10^-6 cm/s
The estimate for compound 4 lay 6.3-fold (0.80 log units) below the measured number, outside the stated range (above it).
By their numbers in this assay, from the lowest: compounds 1 and 3 (each within the scatter of the next); then compounds 2 and 4 (each within the scatter of the next).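

In this assay, for the compounds shown here, the position on the aromatic carbon proves far more responsive than the earlier compounds showed: 4-fluorophenoxy in place of benzyl gives a 14-fold higher number from compound 3 to compound 4 (1.14 log units; beyond the scatter) and, in place of 3,5-dimethylbenzyl, gives a 14-fold higher number from compound 1 to compound 4 (1.14 log units; beyond the scatter) on the same core. With 4-fluorophenoxy in that position, exchanging furan-2-yl for 5-fluoro-2-methoxyphenyl on the chain carbon bound to the amine nitrogen gives no change at the digits printed from compound 2 to compound 4 (within the scatter) and so leaves the number level. No measurement offered here explains the size of the rise.

The exchange alters both the linking atom and the ring fluorine, and a plain phenoxy or a 4-fluorobenzyl group would be needed to separate the two. Going by these compounds, it also remains open whether an amine link at this carbon would give a similar number.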